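Swapping chloro for methoxy at the assay limit

A few compounds are considered here, and "the series" means these few. Any claim that something is new, unique, unknown or untested is made for them only; others in the source may bear on it.

Compound 1 (`Nc1ccccc1NC(=O)CCCNCC(=O)Nc1ccc(Cl)cc1`) was tested in a functional assay on HCT-116 cells (Homo sapiens) for inhibition, read by MTT assay, with a stated time of 2 days (on this read-out higher numbers stand for lower toxicity in this test and lower numbers for higher toxicity in this test), and gives > 100000 nM as a limit, not a number. Compound 2 (`Nc1ccccc1NC(=O)c1ccc(NCC(=O)Nc2ccc([N+](=O)[O-])cc2)cc1`) gives > 100000 nM as a limit too. Compound 3 (`Cc1ccc(NC(=O)CNc2ccc(C(=O)Nc3ccccc3N)cc2)cc1`) likewise gives > 100000 nM as a limit. Compound 4 (`COc1ccc(NC(=O)CNCCCC(=O)Nc2ccccc2N)cc1`) carries methoxy in place of chloro on an aromatic carbon and is otherwise the same as compound 1. Among the measured compounds shown here, the only measured change between neighbours, methyl in place of nitro on an aromatic carbon, is a step that the two limits leave unreadable from compound 2 to compound 3 and offers no size to carry over. The evidence so far is the limit of > 100000 nM in this assay, at which 3 of the 3 values shown sit, and nothing more. No step beyond the scatter is therefore expected in this assay for this swap. The expected change is a number no higher from compound 1 to compound 4 (the limit leaves the size open) in all. For compound 4 the estimated value is 100000 nM with an expected range of 40000 nM to 200000 nM and a further limit is likely.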

Compound 4, concentration lethal to 50% of the cells: > 100000 nM
Compound 4 gave a limit, no number (the forecaster's own chance of this, stated with the estimate: 85%); the middle value sits exactly at the limit.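

Compound 1 and compound 4 each give only a limit in this assay, so the swap of chloro for methoxy yields no readable step: the limit of > 100000 nM in this assay, at which 4 of the 4 values shown sit.

The compounds shown leave open whether this swap changes the read-out at all, as none of them gives an actual number.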